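Swapping a Ring Chloro for a Methoxycarbonyl Group

The source may hold more compounds than are shown below. What is called first, only, known or untested is meant among the compounds shown, and "the series" means these compounds.

Compound 1 `O=C(Nc1cccc(Cl)c1)N[C@H]1CC[C@H](Oc2ccc(F)cc2)CC1` carries a 3-chlorophenyl group on an amide-type nitrogen of the shared core. In a functional assay on CRL2813 cells (Homo sapiens) for cytotoxicity, read by sulforhodamine B assay, with a stated time of 5 days (on this read-out higher numbers stand for weaker inhibition and lower numbers for stronger inhibition), compound 1 gives 5900 nM, the second highest of three numbers; compound 3 `O=C(Nc1ccccc1[N+](=O)[O-])N[C@H]1CC[C@H](Oc2ccc(F)cc2)CC1` gives 3500 nM, and compound 2 `O=C(Nc1ccccc1F)N[C@H]1CC[C@H](Oc2ccc(F)cc2)CC1` gives 17500 nM. Compound 4 `COC(=O)c1cccc(NC(=O)N[C@H]2CC[C@H](Oc3ccc(F)cc3)CC2)c1` differs from compound 1 by methoxycarbonyl in place of chloro on an aromatic carbon. Within the data shown here, no measured step involves methoxycarbonyl, but the changes on this same ring show how far such swaps move this assay: a 3.0-fold higher number from compound 1 to compound 2 (0.47 log units; beyond the scatter), a 1.7-fold lower number from compound 1 to compound 3 (0.23 log units; within the scatter), and a 5.0-fold lower number from compound 2 to compound 3 (0.70 log units; beyond the scatter). A modest shift in either direction is therefore expected, and the estimated step is a 1.4-fold higher number from compound 1 to compound 4 (0.13 log units; within the scatter). Compound 4 is expected to give 8000 nM, with a range from 2500 nM to 25000 nM.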

Compound 4, half-maximal inhibitory concentration: 9200 nM
For compound 4 the middle estimate is 1.2-fold (0.06 log units) below the measured one; the range from low to high includes it.
By their numbers in this assay, from the lowest: compounds 3, 1, 4 and 2 (each within the scatter of the next, the first and the last beyond it).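

Methoxycarbonyl brings four heavy atoms and two hydrogen-bond acceptors where chloro had one heavy atom and no acceptor, yet in this assay the result is a 1.6-fold higher number from compound 1 to compound 4 (0.19 log units; within the scatter). This aromatic carbon therefore tolerates a clearly larger group without a change beyond the scatter. Nothing measured here offers a reason for this result.

Going by these compounds, whether a carboxylic acid or an amine on this same carbon would also stay within the scatter remains open. So does whether a longer ester chain would.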